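Bromine on two cores, read in rat muscle cells

The source may report more compounds than this note shows. Statements on the series, on what has been measured and on what is new or still open speak of the compounds shown alone.

Compound 1 `CC(=O)OC[C@H]1O[C@@H](N2C(=O)/C(=C3/C(=O)Nc4ccccc43)c3ccccc32)[C@H](OC(C)=O)[C@@H](OC(C)=O)[C@@H]1OC(C)=O` and compound 2 `CC(=O)OC[C@H]1O[C@@H](N2C(=O)/C(=C3/C(=O)Nc4ccc(Br)cc43)c3ccccc32)[C@H](OC(C)=O)[C@@H](OC(C)=O)[C@@H]1OC(C)=O` share one core, while compound 3 `CC(=O)OC[C@H]1O[C@@H](N2C(=O)/C(=C3/C(=O)Nc4ncccc43)c3ccccc32)[C@H](OC(C)=O)[C@@H](OC(C)=O)[C@@H]1OC(C)=O` and compound 4 `CC(=O)OC[C@H]1O[C@@H](N2C(=O)/C(=C3/C(=O)Nc4ncc(Br)cc43)c3ccccc32)[C@H](OC(C)=O)[C@@H](OC(C)=O)[C@@H]1OC(C)=O` share another; how the core of compound 3 differs from the core of compound 1 is not broken down here. In an ADME assay on L6 cells (Rattus norvegicus) for cytotoxicity, read by resazurin assay, with a stated time of 72 h (a lower number here means a stronger inhibitor, a higher number a weaker inhibitor), compound 1 gives 4530 nM, compound 2 gives 7700 nM, and compound 3 gives 27400 nM, the highest of the three measured numbers. The change from compound 1 to compound 2 is bromo in place of hydrogen on an aromatic carbon and produced a 1.7-fold higher number from compound 1 to compound 2 (0.23 log units; within the scatter). The change from compound 3 to compound 4 is bromo in place of hydrogen on an aromatic carbon. It is the same kind of change, but the ring that receives the bromo is a six-membered aromatic ring with 1 nitrogen rather than a six-membered aromatic ring of carbon only, and the bromo sits two atoms from the ring nitrogen. Compound 4 has not yet been measured in this assay. For the measured compounds named here, the step is expected to be a 1.5-fold higher number from compound 3 to compound 4 (0.16 log units; within the scatter), which rests on the only comparable step known, because bromo in place of hydrogen gave a 1.7-fold higher number from compound 1 to compound 2 (0.23 log units; within the scatter) on the other core. Going by the values given here, with only one prior example, and that one within the scatter, the expectation is weak, and compound 3 itself shows that the second core reads differently. Compound 4 is therefore estimated at 40000 nM in this assay, with a range from 18000 nM to 90000 nM.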

Compound 4, half-maximal inhibitory concentration: 26100 nM
The estimate for compound 4 lay 1.5-fold (0.19 log units) above the measured number, within the range that was stated.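

Bromo in place of hydrogen on an aromatic carbon gave a 1.0-fold lower number from compound 3 to compound 4 (0.02 log units; within the scatter) in this assay, so on this core, as on the core of compound 1, the step stays within the scatter. The two cores do not separate in how they take this change, and the small step seen on the first core carries over to the second as a similarly small one: the same change on two cores in this assay, a 1.7-fold higher number (0.23 log units; within the scatter) from compound 1 to compound 2 and a 1.0-fold lower number (0.02 log units; within the scatter) from compound 3 to compound 4, 1.8-fold (0.25 log units) apart, within the scatter of two such steps. For the compounds shown here, this is agreement between only two pairs, for one group, and neither step is large enough to show that a change of real size would carry across; it also does not show that bromo would behave alike on a further core or at another place on these rings.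

On these data alone, only hydrogen and bromo appear at this place on either core, so it remains open whether chloro, a methoxy group or an amine there would leave the number in this assay just as unmoved. Also open, as far as these compounds go, is whether the acetyl esters carried by all four compounds bear on the reading, a question that free hydroxyl groups in their stead could address.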